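Swapping the Amine Tail of Compound 3

The source may report more compounds than this note shows. Statements on the series, on what has been measured and on what is new or still open speak of the compounds shown alone.

In a functional assay on MCF7 cells (Homo sapiens) for antiproliferative activity, read by MTT assay, with a stated time of 72 h (on this read-out higher numbers stand for weaker inhibition and lower numbers for stronger inhibition), compound 2 (`O=C(N/N=C/c1ccccc1)Nc1ccc(Oc2ccnc3[nH]ccc23)cc1`) gives 1510 nM as its result. In this assay compound 3 (`CCN(CC)CCCn1cccc1/C=N/NC(=O)Nc1ccc(Oc2ccnc3[nH]ccc23)c(F)c1`) gives 3390 nM as the higher of the two numbers, so it inhibits less strongly than compound 2, by a gap beyond the usual scatter. Compound 1 (`N#Cc1ccc(/C=N/NC(=O)Nc2ccc(Oc3ccnc4[nH]ccc34)c(F)c2)cc1`) is reported as "not active" (no number reported) with no number to compare.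

Compound 4 (`CN1CCN(CCCn2cccc2/C=N/NC(=O)Nc2ccc(Oc3ccnc4[nH]ccc34)c(F)c2)CC1`) has not yet been measured. The change from compound 3 is 4-methylpiperazin-1-yl in place of diethylamino on a saturated chain carbon, three bonds along the chain from an aromatic nitrogen. Among the compounds with values here, no measured pair shows a swap of this kind, so the expectation rests on compound 3 at 3390 nM as the closest measured neighbour, and no change beyond the scatter is expected in this assay for this step. The estimated step runs a 1.4-fold lower number from compound 3 to compound 4 (0.13 log units; within the scatter) and stays within the usual scatter. Compound 4 is estimated at 2500 nM with 700 nM to 9000 nM as the expected range.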

Compound 4, half-maximal inhibitory concentration: 3740 nM
For compound 4 the middle estimate is 1.5-fold (0.17 log units) below the measured one, and the stated range covers the measured number.
By their numbers in this assay, from the lowest: compound 2; then compounds 3 and 4 (each within the scatter of the next).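

In this assay, putting 3-(4-methylpiperazin-1-yl)propyl in place of 3-(diethylamino)propyl gives a 1.1-fold higher number from compound 3 to compound 4 (0.04 log units; within the scatter), so the two compounds cannot be told apart on this read-out. This is the first pair shown that differs in one place only, and it shows that this position accepts an open diethylamino end or a six-membered non-aromatic ring with 2 hetero atoms with no difference beyond the scatter. No measured property is available to explain why the two groups give such similar results.

As far as these compounds go, whether a morpholine or piperidine ring at the end of the same chain would give a similar number remains open. A longer chain between the aromatic nitrogen and the amine is also untested by the compounds shown here.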